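Swapping the fluorophenyl group on a low-toxicity pair

The source may report more compounds than this note shows. Statements on the series, on what has been measured and on what is new or still open speak of the compounds shown alone.

In an ADME assay on L02 cells (Homo sapiens) for cytotoxicity, read by MTT assay, with a stated time of 24 h (on this read-out higher numbers stand for weaker inhibition and lower numbers for stronger inhibition), compound 1 `CN1C/C(=C\c2ccc(C(F)(F)F)cc2)C(=O)/C(=C/c2ccccc2F)C1` gives 18600 nM and compound 2 `CN1C/C(=C\c2cccc([N+](=O)[O-])c2)C(=O)/C(=C/c2ccccc2F)C1` gives 13500 nM. These two values lie within the usual scatter of each other, so compound 2 stands level with compound 1 on the numbers available, and the pair sets one reference region for the series.

The next entry is compound 3 `CN1C/C(=C\c2cccc([N+](=O)[O-])c2)C(=O)/C(=C/c2ccc(Cl)cc2Cl)C1`, which has not yet been measured. It differs from compound 2 by 2,4-dichlorophenyl in place of 2-fluorophenyl on a double-bonded chain carbon bound to a double-bonded ring carbon.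

Within the data shown here, no measured compound here carries the 2,4-dichlorophenyl group, and no measured step shows what this exchange does. The expectation therefore rests on compound 2 at 13500 nM, and no step beyond the scatter is expected in this assay. The estimated step is a 1.2-fold lower number from compound 2 to compound 3 (0.09 log units; within the scatter), and its direction is only weakly held. The estimate for compound 3 is 11000 nM, with an expected range of 4500 nM to 25000 nM.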

Compound 3, half-maximal inhibitory concentration: 14000 nM
For compound 3 the middle estimate is 1.3-fold (0.10 log units) below the measured one; the measured number falls inside the stated range.
By their numbers in this assay, from the lowest: compounds 2, 3 and 1 (each within the scatter of the next).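

In this assay, among these compounds, 2,4-dichlorophenyl in place of 2-fluorophenyl on a double-bonded chain carbon bound to a double-bonded ring carbon gives a 1.0-fold higher number from compound 2 to compound 3 (0.02 log units; within the scatter), the first measured exchange at this position. With the rest of compound 2 held fixed, two chlorine atoms in place of one fluorine atom leave compound 3 level with compound 2, so in this one pair the read-out does not separate the two halogenated phenyl groups. Nothing measured here explains why the pair stands level.

Going by these compounds, both groups compared at this position are halogenated phenyl rings, so it remains open whether the read-out would stay level with a carboxylic acid or an amine on the phenyl ring, or with a pyridine ring in place of the phenyl ring. On these data alone, it also remains open whether the same exchange would read the same way on compound 1, since this single step comes from the partner group of compound 2 only.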